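The source may report more compounds than this note shows. Statements on the series, on what has been measured and on what is new or still open speak of the compounds shown alone.

Measured compounds:

Compound 1, `COc1ccc(-c2cc3ccccc3nc2/C=C/C(=O)c2ccc(N)cc2)cc1`, gives 6920 nM in a functional assay on MCF7 cells (Homo sapiens) for antiproliferative activity, read by XTT assay, with a stated time of 72 h; a higher number here means a weaker inhibitor, a lower number a stronger inhibitor.
Compound 2, `COc1ccc(-c2cc3ccccc3nc2/C=C/C(=O)c2ccc([N+](=O)[O-])cc2)cc1`, gives 4110 nM in this assay.
Compound 3, `COc1ccc(-c2cc3ccccc3nc2/C=C/C(=O)c2ccco2)cc1`, gives 710 nM in this assay.

All three share the same core and differ only in the group attached to the carbonyl carbon. Compound 3 has the lowest number of the three: the steps of a 9.7-fold lower number from compound 1 to compound 3 (0.99 log units; beyond the scatter) and a 5.8-fold lower number from compound 2 to compound 3 (0.76 log units; beyond the scatter) are both beyond the scatter, so compound 3 is the strongest inhibitor among the measured compounds. Between the two phenyl-bearing compounds the step of a 1.7-fold lower number from compound 1 to compound 2 (0.23 log units; within the scatter) stays within the scatter.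

Compound 4, `COc1ccc(-c2cc3ccccc3nc2/C=C/C(=O)c2c[nH]c3ccccc23)cc1`, has not yet been measured. The change from compound 3 is 1H-indol-3-yl in place of furan-2-yl on a carbonyl carbon. The two steps that bear on it are those that replaced the group on the carbonyl carbon, and both were modest and both favoured the furan. For the measured compounds named here, no measured step involves an indolyl group, so the direction of the new step is uncertain; since every group tried in place of the furan gave a higher number, a modest rise toward a weaker inhibitor is expected, a 2.1-fold higher number from compound 3 to compound 4 (0.32 log units; beyond the scatter). Compound 4 is therefore estimated at 1500 nM, with a likely range from 400 nM to 6000 nM.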

Compound 4, half-maximal inhibitory concentration: > 10000 nM
Compound 4: a limit, no number; the forecaster's own chance of this, stated with the estimate: 5%; at least 6.6-fold (0.82 log units) between middle value and limit.
By their numbers in this assay, from the lowest: compound 3; then compounds 2 and 1 (each within the scatter of the next). At a limit, above all of these: compound 4.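

Compound 4 ends at a limit of the assay rather than at a number: the limit of > 10000 nM in this assay, at which 1 of the 4 values shown sits.

On this carbonyl carbon, the entering 1H-indol-3-yl keeps a five-membered aromatic ring with 1 hetero atom, as furan-2-yl does, yet the change gives an at least 14-fold higher number from compound 3 to compound 4 (1.14 log units; beyond the scatter), so keeping such a ring is not enough to hold the low number of the furan compound. The earlier compounds shown here showed only modest steps at this place, and the new compound also separates clearly from the nitro compound, with an at least 2.4-fold higher number from compound 2 to compound 4 (0.38 log units; beyond the scatter), while against the amino compound the comparison stays unsettled, with an at least 1.4-fold higher number from compound 1 to compound 4 (0.15 log units; that floor lies within the scatter).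

From the compounds shown here alone, how far the true value of compound 4 lies past its limit stays open, and so does the size of its gap to compound 1. Also open, going by these compounds, is which part of the change carries the loss, the added six-membered aromatic ring or the swap of the ring oxygen for a nitrogen bearing a hydrogen, and a benzofuran-3-yl or a pyrrol-2-yl group on the carbonyl carbon would pull these two apart.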